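A few compounds are considered here, and "the series" means these few. Any claim that something is new, unique, unknown or untested is made for them only; others in the source may bear on it.

In a functional assay on MGC-803 cells (Homo sapiens) for cytotoxicity, read by MTT assay, with a stated time of 72 h (a lower number here means a stronger inhibitor, a higher number a weaker inhibitor), compound 3 `Fc1ccc(Nc2nc(SCc3ccc(C(F)(F)F)cc3)nc3ccccc23)cc1` gives 9620 nM, the lowest of the two numbers available. Compound 1 `FC(F)(F)c1ccc(CSc2nc(N3CCCCC3)c3ccccc3n2)cc1` gives 18600 nM, and the gap between them is a 1.9-fold lower number from compound 1 to compound 3 (0.29 log units; within the scatter). For compound 2 `FC(F)(F)c1ccc(CSc2nc(Nc3ccccc3C(F)(F)F)c3ccccc3n2)cc1` this assay reports only a limit, > 50000 nM. Compound 4 `O=[N+]([O-])c1ccc(Nc2nc(SCc3ccc(C(F)(F)F)cc3)nc3ccccc23)cc1` has not yet been measured; it differs from compound 3 by nitro in place of fluoro on an aromatic carbon. Within the data shown here, the only measured step touching that phenyl group is an at least 5.1-fold lower number from compound 2 to compound 3 (0.71 log units; beyond the scatter), but it exchanges the whole phenyl rather than one substituent on it, so it gives no direct guide to the nitro change. The step from compound 3 to compound 4 is therefore expected to be small, a 1.1-fold lower number from compound 3 to compound 4 (0.03 log units; within the scatter). The estimate for compound 4 is 9000 nM, within a range from 2500 nM to 35000 nM.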

Compound 4, half-maximal inhibitory concentration: 8170 nM
For compound 4 the middle estimate is 1.1-fold (0.04 log units) above the measured one; the range from low to high includes it.
By their numbers in this assay, from the lowest: compounds 4, 3 and 1 (each within the scatter of the next, the first and the last beyond it). At a limit, above all of these: compound 2.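

On the aromatic carbon para to a large group, a 1.2-fold lower number from compound 3 to compound 4 (0.07 log units; within the scatter), so in this assay nitro and fluoro cannot be told apart at this position. Against the piperidin-1-yl compound, the 4-nitrophenyl compound shows a 2.3-fold lower number from compound 1 to compound 4 (0.36 log units; beyond the scatter), a separation that the 4-fluorophenyl compound did not reach beyond the scatter. One further step starts from a limit, not a number, and reads an at least 6.1-fold lower number from compound 2 to compound 4 (0.78 log units; beyond the scatter): the limit of > 50000 nM in this assay, at which 1 of the 4 values shown sits.

On these data alone, whether an amine or a carboxylic acid at this position would give a similar number remains open. So does whether any group placed there moves the number beyond the scatter.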